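The source may report more compounds than this note shows. Statements on the series, on what has been measured and on what is new or still open speak of the compounds shown alone.

Measured so far: compound 1 `CC(=O)c1cc(C(=O)N[C@@H](C)Cn2ccc(-c3cc(F)c(C#N)c(Cl)c3)n2)n[nH]1` with 1100 nM; compound 2 `CC(O)c1cccc(C(=O)N[C@@H](C)Cn2ccc(-c3ccc(C#N)c(Cl)c3)n2)c1` with 2280 nM; compound 3 `C[C@@H](Cn1ccc(-c2ccc(C#N)c(Cl)c2)n1)NC(=O)c1cccc(OCC(O)CO)c1` with 740 nM.

All three were tested in a functional assay on LNCaP cells (Homo sapiens) for antiproliferative activity, read by CCK-8 assay, with a stated time of 6 days; a higher number here means a weaker inhibitor, a lower number a stronger inhibitor. Among them compound 2 stands highest, that is, it is the weakest of the three; compound 1 sits closer to it and compound 3 furthest from it. For the measured compounds named here, the step from compound 2 to compound 3 is the only one-place change available, and it gave a 3.1-fold lower number from compound 2 to compound 3 (0.49 log units; beyond the scatter), a change on the aromatic ring that hangs from the amide carbonyl.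

Compound 4 `CC(=O)c1ccc(C(=O)N[C@@H](C)Cn2ccc(-c3ccc(C#N)c(Cl)c3)n2)cc1` is the untested member. It differs from compound 2 by 4-acetylphenyl in place of 3-(1-hydroxyethyl)phenyl on a carbonyl carbon, placed on a carbonyl carbon whose other neighbour is the amide-type nitrogen. The change swaps one group on that ring for another of the same count of heavy atoms, giving up the single hydrogen-bond donor. Going by the values given here, the one measured step on this ring moved the number down; compound 1, which also carries an acetyl group though on a different ring and with a further fluorine, gives a lower number than compound 2 too. Among the compounds with values here, a modest drop is therefore expected, a 1.9-fold lower number from compound 2 to compound 4 (0.28 log units; within the scatter) in size, with wide uncertainty since no measured pair makes this exact swap. The estimated value for compound 4 is 1200 nM, within 450 nM to 3200 nM.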

Compound 4, half-maximal inhibitory concentration: 3600 nM
Beside the measured number, compound 4's estimate is 3.0-fold (0.48 log units) below it, outside the stated range (above it).
By their numbers in this assay, from the lowest: compounds 3 and 1 (each within the scatter of the next); then compounds 2 and 4 (each within the scatter of the next).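

In this assay, putting 4-acetylphenyl in place of 3-(1-hydroxyethyl)phenyl on the carbonyl carbon gives a 1.6-fold higher number from compound 2 to compound 4 (0.20 log units; within the scatter), so compound 2 and compound 4 cannot be told apart in this test. The result shows that, for this pair, a group with the same count of heavy atoms but no hydrogen-bond donor leaves the number within the scatter, whereas the earlier change to 2,3-dihydroxypropoxy gave a 3.1-fold lower number from compound 2 to compound 3 (0.49 log units; beyond the scatter). Nothing available explains why this swap left the number within the scatter.

The swap alters both the group and its place on the ring, and the compounds shown do not separate these two changes. Also open, on these data alone, is how 3-acetylphenyl, or a phenyl ring carrying an amine or a carboxylic acid, would compare with compound 2 at this carbonyl carbon.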